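A few compounds are considered here, and "the series" means these few. Any claim that something is new, unique, unknown or untested is made for them only; others in the source may bear on it.

Measured in a functional assay on A-375 cells (Homo sapiens) for cytotoxicity, read by MTT assay, with a stated time of 48 h; on this read-out higher numbers stand for weaker inhibition and lower numbers for stronger inhibition:
compound 1 `CC1(C)[C@H](C(=O)OC(c2ccccc2)c2ccccc2)N2C(=O)/C(=C/C(=O)c3ccc([N+](=O)[O-])cc3)[C@H]2[S+]1[O-]` gives 48200 nM
compound 2 `CC1(C)S[C@@H]2/C(=C\C(=O)OC(c3ccccc3)c3ccccc3)C(=O)N2[C@H]1C(=O)OC(c1ccccc1)c1ccccc1` gives 9100 nM
compound 3 `CC(=O)/C=C1/C(=O)N2[C@@H]1SC(C)(C)[C@@H]2C(=O)OC(c1ccccc1)c1ccccc1` gives 63000 nM

Compound 3 carries the highest number of the three. Its gap to compound 1 lies within the scatter, so no order between those two is claimed; compound 2 stands lower, beyond the scatter. Compound 4 `CC1(C)S[C@@H]2/C(=C\C(=O)c3ccccc3)C(=O)N2[C@H]1C(=O)OC(c1ccccc1)c1ccccc1` is not yet measured in this assay. Against compound 3 the change is phenyl in place of methyl on a carbonyl carbon, acetyl to benzoyl. For the measured compounds named here, no pair of measured compounds isolates this change; compound 1 also bears a phenyl-based ketone, with other differences, and its number sits within the scatter of compound 3. For compound 4 a small lowering is expected, probably not beyond the scatter, a step of a 1.8-fold lower number from compound 3 to compound 4 (0.26 log units; within the scatter). The estimate for compound 4 is 35000 nM, range 12000 nM to 100000 nM.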

Compound 4, half-maximal inhibitory concentration: 22800 nM
Compound 4: middle estimate off by 1.5-fold (0.19 log units), on the high side; the measured number falls inside the stated range.
By their numbers in this assay, from the lowest: compound 2; then compound 4; then compounds 1 and 3 (each within the scatter of the next).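

In this assay, for the compounds shown here, the first single-place comparison shows that this position responds to substitution, with a 2.8-fold lower number from compound 3 to compound 4 (0.44 log units; beyond the scatter) when phenyl replaces methyl on a carbonyl carbon. Going by these compounds alone, the step is modest and rests on this one pair, so acetyl to benzoyl is the only change read here. No measurement on hand accounts for it.

Going by these compounds, whether a cyclohexyl, a longer alkyl chain or a phenyl bearing an amine would shift the number in the same direction remains open. On these data alone, whether the aromatic ring itself matters, rather than the added carbons, also remains open.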